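From Fluoro to Trifluoromethyl on One Aromatic Carbon

The source may report more compounds than this note shows. Statements on the series, on what has been measured and on what is new or still open speak of the compounds shown alone.

In an ADME assay on HepG2 2.2.15 cells (Homo sapiens) for cytotoxicity, read by CCK-8 assay, with a stated time of 8 days (on this read-out higher numbers stand for lower toxicity in this test and lower numbers for higher toxicity in this test), compound 1 `Cc1cccc(-c2cc(NC(=O)c3ccccc3O)c[nH]c2=O)c1` gives 98800 nM and compound 2 `Cc1cccc(-c2cc(NC(=O)c3ccc(F)cc3O)c[nH]c2=O)c1` gives 37200 nM as the lower of the two numbers. Compound 3 `Cc1cccc(-c2cc(NC(=O)c3ccc(C(F)(F)F)cc3O)c[nH]c2=O)c1` differs from compound 2 by trifluoromethyl in place of fluoro on an aromatic carbon. Among the measured compounds shown here, the one measured step that bears on this is fluoro in place of hydrogen, a 2.7-fold lower number from compound 1 to compound 2 (0.42 log units; beyond the scatter) and modest, though beyond the scatter. A further modest fall in this assay is therefore expected, with a 1.9-fold lower number from compound 2 to compound 3 (0.27 log units; within the scatter) as the estimated step. For compound 3 the estimated value is 20000 nM within an expected range from 7000 nM to 55000 nM in this same test.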

Compound 3, half-maximal cytotoxic concentration: 24200 nM
The estimate for compound 3 lay 1.2-fold (0.08 log units) below the measured number; measured number inside the range.
By their numbers in this assay, from the lowest: compounds 3 and 2 (each within the scatter of the next); then compound 1.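

Replacing fluoro with trifluoromethyl on this aromatic carbon, para to a large group, gives a 1.5-fold lower number from compound 2 to compound 3 (0.19 log units; within the scatter), so this assay does not separate these two groups. Against hydrogen, however, trifluoromethyl gives a 4.1-fold lower number from compound 1 to compound 3 (0.61 log units; beyond the scatter), so two different groups at this position now both read lower than hydrogen, and the larger step belongs to the group with more heavy atoms. No measurement here gives a reason for these numbers. The compounds shown leave open how an amine or a carboxylic acid on this same carbon would read. They also leave open whether the same change would give a similar step on another core.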